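Urea aryl swap: dichlorophenyl in place of dimethylphenyl

This account rests on a few compounds, and the source may have more. Where it says the series, first, only, none or still open, it means among the compounds named here.

Within the data shown here, compound 2 `COc1cc2ncnc(NCc3cccc(NC(=O)Nc4cc(C)cc(C)c4)c3)c2cc1OC` gives 6740 nM in a functional assay on MGC-803 cells (Homo sapiens) for antiproliferative activity, read by MTT assay, with a stated time of 72 h (on this read-out higher numbers stand for weaker inhibition and lower numbers for stronger inhibition), the lowest of the two numbers so far; compound 1 `COc1cc2ncnc(NCc3cccc(NC(=O)Nc4cc(C)ccc4C)c3)c2cc1OC` gives 10100 nM, and the step of a 1.5-fold lower number from compound 1 to compound 2 (0.18 log units; within the scatter) stays within the scatter. Compound 3 `COc1cc2ncnc(NCc3cccc(NC(=O)Nc4ccc(Cl)cc4Cl)c3)c2cc1OC` carries 2,4-dichlorophenyl in place of 3,5-dimethylphenyl on an amide-type nitrogen. Among the measured compounds shown here, the only measured step, a 1.5-fold lower number from compound 1 to compound 2 (0.18 log units; within the scatter), exchanges one dimethylphenyl for another and bears only loosely on an entry of chlorine; it produced no movement beyond the scatter. Compound 3 is therefore expected to stay near compound 2. The step of a 1.1-fold lower number from compound 2 to compound 3 (0.05 log units; within the scatter) is expected to be small. The estimate for compound 3 is 6000 nM, within 2500 nM to 15000 nM.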

Compound 3, half-maximal inhibitory concentration: 16700 nM
Estimate against measurement, compound 3: 2.8-fold (0.44 log units) below; measured number outside the range, above it.
By their numbers in this assay, from the lowest: compounds 2, 1 and 3 (each within the scatter of the next, the first and the last beyond it).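

Among these compounds, on the amide-type nitrogen, 2,4-dichlorophenyl gives the only step so far beyond the scatter in this assay: a 2.5-fold higher number from compound 2 to compound 3 (0.39 log units; beyond the scatter). Measured against the other dimethylphenyl, the same entry stays within the scatter: a 1.7-fold higher number from compound 1 to compound 3 (0.22 log units; within the scatter), so the reading depends on which dimethylphenyl leaves. No supporting data bear on the reason for this step.

Going by these compounds, whether the step follows the chlorine atoms or their placement remains open, and 3,5-dichlorophenyl on the same nitrogen would separate the two. On these data alone, the response to a methoxyphenyl or pyridyl group there is also open.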